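Trimming One Methyl from the Amine of Compound 2

The source may report more compounds than this note shows. Statements on the series, on what has been measured and on what is new or still open speak of the compounds shown alone.

Compound 2 `CC(CC(C)(C)C)Oc1cccc2ccc(N(C)C)nc12` is a close relative of compound 1 `CC(CC(C)(C)C)Oc1cccc2ccc(N3CCCCC3)nc12`; the two share a core and differ only in the amine on an aromatic carbon. In a functional assay on IMR-32 cells with melanin-concentrating hormone receptor 1 (Homo sapiens) as the target, read by fluorescence (a higher number here means a weaker inhibitor, a lower number a stronger inhibitor), compound 1 reaches only a limit of the assay, > 10000 nM. Compound 2 likewise gives only a limit in this assay, > 10000 nM. The step between them, a step that the two limits leave unreadable from compound 1 to compound 2, cannot be sized since both values sit at the same limit (the limit of > 10000 nM in this assay, at which 2 of the 2 values shown sit). Compound 2 thus stands at the edge of what this assay can report, with no number of its own.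

Compound 3 `CNc1ccc2cccc(OC(C)CC(C)(C)C)c2n1` is made from compound 2 by a single change: hydrogen in place of methyl on a nitrogen on an aromatic ring. No measured step bears directly on this change; the only step shown, piperidin-1-yl to dimethylamino, is unreadable. With both neighbours at the limit, no direction can be read, and the expectation is no step beyond the scatter, a step that the limit leaves unreadable from compound 2 to compound 3. Compound 3 is therefore expected to give about 20000 nM, between 5000 nM and 80000 nM, most likely again reported only as a limit.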

Compound 3, half-maximal inhibitory concentration: 6090 nM
Compound 3: middle estimate off by 3.3-fold (0.52 log units), on the high side, and the stated range covers the measured number.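

In this assay compound 3 gives 6090 nM, which shows that with methylamino on the aromatic carbon of the shared core the assay can return an actual number. Compound 1 and compound 2 give no such number: the limit of > 10000 nM in this assay, at which 2 of the 3 values shown sit.

Hydrogen in place of methyl on the nitrogen gives an at least 1.6-fold lower number from compound 2 to compound 3 (0.21 log units; that floor lies within the scatter), and the wider change from piperidin-1-yl to methylamino gives an at least 1.6-fold lower number from compound 1 to compound 3 (0.21 log units; that floor lies within the scatter). On these data alone, both steps are only floors that sit within the scatter, so their true size stays unknown, and what is new is simply that a nitrogen carrying one methyl and one hydrogen is compatible with a measurable inhibitor.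

The compounds shown leave open what happens with the plain amino group, where the remaining methyl is also replaced by hydrogen, and whether a slightly longer chain on the nitrogen, as in ethylamino, keeps a measurable number. They also leave open how much of the value of compound 3 depends on the branched ether chain, since that chain is the same throughout and no shorter chain or amine in its place appears here.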